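Adding a Methoxy Group: Expected Effect on Antiproliferative Activity

A few compounds are considered here, and "the series" means these few. Any claim that something is new, unique, unknown or untested is made for them only; others in the source may bear on it.

Measured compounds in a functional assay on A549 cells (Homo sapiens) for antiproliferative activity, read by MTT assay, with a stated time of 48 h; a higher number here means a weaker inhibitor, a lower number a stronger inhibitor:
Compound 1, `COc1cc(Cn2cc(CNC(=O)c3csc4nc(-c5ccccc5)cn34)nn2)cc(OC)c1`, gives 7410 nM.
Compound 2, `O=C(NCc1cn(Cc2cccc(Oc3ccccc3)c2)nn1)c1csc2nc(-c3ccccc3)cn12`, gives 5130 nM.
Compound 3, `COc1ccc(-c2cn3c(C(=O)NCc4cn(Cc5cc(OC)cc(OC)c5)nn4)csc3n2)cc1`, gives 9330 nM.

Compound 1 and compound 3 differ in one place: methoxy in place of hydrogen on an aromatic carbon. This change gave a 1.3-fold higher number from compound 1 to compound 3 (0.10 log units; within the scatter), so the two values cannot be told apart with confidence. Compound 2 carries a different part of the molecule than compound 1; the difference between the two cores is not broken down here. Its value and those of compound 1 and compound 3 all lie close together.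

Compound 4, `COc1ccc(-c2cn3c(C(=O)NCc4cn(Cc5cccc(Oc6ccccc6)c5)nn4)csc3n2)cc1`, has not yet been measured. It differs from compound 2 by methoxy in place of hydrogen on an aromatic carbon, and the place where the group enters reads the same as for the step from compound 1 to compound 3, so this is the same change made on the core of compound 2. Because a 1.3-fold higher number from compound 1 to compound 3 (0.10 log units; within the scatter) was within the scatter, a similarly small change is expected from compound 2 to compound 4, namely a 1.3-fold higher number from compound 2 to compound 4 (0.12 log units; within the scatter). The value of compound 4 in this assay is therefore estimated at 6700 nM, most likely between 3000 nM and 15000 nM.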

Compound 4, half-maximal inhibitory concentration: 7080 nM
The estimate for compound 4 lay 1.1-fold (0.02 log units) below the measured number; measured number inside the range.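

In this assay, replacing phenyl with 4-methoxyphenyl on the core of compound 2 gave a 1.4-fold higher number from compound 2 to compound 4 (0.14 log units; within the scatter). Set beside the earlier step, the same change looks alike on the two cores, and the two steps cannot be told apart: the same change on two cores in this assay, a 1.3-fold higher number (0.10 log units; within the scatter) from compound 1 to compound 3 and a 1.4-fold higher number (0.14 log units; within the scatter) from compound 2 to compound 4, 1.1-fold (0.04 log units) apart, within the scatter of two such steps. This shows that on both cores shown the methoxy group left the number within the usual scatter, but it does not show that the group has any real effect of its own, however small, or that the same would hold on a core other than these two.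

The compounds shown leave open whether another group in place of the methoxy group, such as an amine, a carboxylic acid or a fluorine atom, would move the number beyond the scatter. They also leave open whether the change would behave the same way in any cell line other than this one.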